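A few compounds are considered here, and "the series" means these few. Any claim that something is new, unique, unknown or untested is made for them only; others in the source may bear on it.

Compound 1 `CN1C(=O)[C@@]2(c3ccccc31)N(C)C[C@@H](c1ccc(F)cc1)[C@@]21Cc2ccccc2C1=O` gives 25.5% in a functional assay on the whole organism (strain Wister albino) for inhibition, with Rattus norvegicus as the target, read by paw edema, with stated times of 1 h and 4 h, at a dose of 50 mg/kg by the intraperitoneal route; on this read-out higher numbers stand for more inhibition at the one dose given (going by the name of the read-out) and lower numbers for less inhibition.
Compound 2 `CN1C(=O)[C@@]2(c3ccccc31)N(C)C[C@@H](c1ccc(Cl)cc1)[C@@]21Cc2ccccc2C1=O` gives 8.5% in this assay.
Compound 3 `Cc1ccc([C@@H]2CN(C)[C@]3(C(=O)N(C)c4ccccc43)[C@]23Cc2ccccc2C3=O)cc1` gives 13.9% in this assay.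

These three compounds share one core and differ only in the group on the outer aromatic ring. Compound 3 stands second highest of the three numbers. Against compound 1 the gap is real: the step was a number 11.6 percentage points lower from compound 1 to compound 3 (beyond the scatter). Against compound 2 the gap is not: the step of a number 5.4 percentage points higher from compound 2 to compound 3 (within the scatter) lies within the scatter, so compound 2 and compound 3 cannot be told apart on these numbers.

Compound 4 `COc1ccc([C@@H]2CN(C)[C@]3(C(=O)N(C)c4ccccc43)[C@]23Cc2ccccc2C3=O)cc1` is the next compound in the series. It differs from compound 3 by methoxy in place of methyl on an aromatic carbon. All three known steps are swaps of the group on that same aromatic carbon, and none of them involves a methoxy group. The largest of them, a number 17 percentage points lower from compound 1 to compound 2 (beyond the scatter), was modest; the others were modest or within the scatter. A change of one small group for another at this position has therefore produced steps of modest size at most, and nothing points in a fixed direction. Compound 4 is estimated to give 15%, with a range from 4% to 28%. The expected step is a number 1.1 percentage points higher from compound 3 to compound 4 (within the scatter), which would stay within the scatter.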

Compound 4, a percentage reported as inhibition, in the whole organism at one dose (the size of the read-out at that dose, not a potency): 3.8%
The estimate for compound 4 lay 11.2 percentage points above the measured number; measured number outside the range, below it.
By their numbers in this assay, from the lowest: compounds 4, 2 and 3 (each within the scatter of the next, the first and the last beyond it); then compound 1.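

Of the four groups shown on this aromatic carbon, methoxy alone brings an oxygen atom and a hydrogen-bond acceptor, and in this assay the swap from methyl gives a number 10.1 percentage points lower from compound 3 to compound 4 (beyond the scatter), so a change of only one heavy atom can move the number by a modest but real amount. Against chloro the same group gives a number 4.7 percentage points lower from compound 2 to compound 4 (within the scatter), which means these two compounds cannot be told apart, whereas against fluoro it gives a number 21.7 percentage points lower from compound 1 to compound 4 (beyond the scatter), the largest step seen so far at this position, and compound 1 remains the highest of the four, with its step to each of the others beyond the scatter. Nothing shown here explains why the methoxy compound reads as it does.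

The compounds shown leave open how an amine, a carboxylic acid or a longer chain such as ethoxy would read on this aromatic carbon, and whether a hydroxy group, which also carries an oxygen, would fall with compound 4 or nearer compound 1. Going by these compounds, each number also comes from one dose, so how these compounds compare across other doses remains unknown.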